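The compounds below may be only part of what the source reports. "The series", "measured", "known", "first", "only" and "open" are said of these compounds alone.

Compound 1, `O=C1O/C(=C\Cn2cc(-c3cc(F)cc(F)c3)nn2)C(OCc2ccccc2)=C1OCc1ccccc1`: in a functional assay on A549 cells (Homo sapiens) for antiproliferative activity, read by MTT assay, with a stated time of 72 h (on this read-out lower numbers stand for stronger inhibition and higher numbers for weaker inhibition), compound 1 gives > 100000 nM, which is a limit of the assay rather than a number.
Compound 2, `O=C1O[C@H]([C@@H](O)Cn2cc(-c3cccc(O)c3)nn2)C(OCc2ccccc2)=C1OCc1ccccc1`: in this assay compound 2 gives 59900 nM.

Going by the values given here, compound 2 thus stands as the only measured compound with a number; the other value is a limit, as in the limit of > 100000 nM in this assay, at which 1 of the 2 values shown sits. Compound 3, `O=C1O[C@H]([C@@H](O)Cn2cc(CNS(=O)(=O)c3ccc(F)cc3)nn2)C(OCc2ccccc2)=C1OCc1ccccc1`, differs from compound 2 by (((4-fluorophenyl)sulfonyl)amino)methyl in place of 3-hydroxyphenyl on an aromatic carbon. Among the compounds with values here, no step between measured compounds is known, so the size of this change cannot be read from the data; in this assay a step within the usual scatter, or a modest weakening, is expected. Compound 3 is estimated at 75000 nM, within 20000 nM to 250000 nM. The expected step is a 1.3-fold higher number from compound 2 to compound 3 (0.10 log units; within the scatter).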

Compound 3, half-maximal inhibitory concentration: 22500 nM
Estimate against measurement, compound 3: 3.3-fold (0.52 log units) above; low and high end bracket the measured number.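

Compound 3 shows that the number responds to the group on the aromatic carbon of the five-membered aromatic ring with 3 nitrogen: replacing 3-hydroxyphenyl with (((4-fluorophenyl)sulfonyl)amino)methyl gives a 2.7-fold lower number from compound 2 to compound 3 (0.43 log units; beyond the scatter) in this assay. Going by these compounds alone, this modest gain is the first measured step. Nothing measured here explains it.

Which part of the entering group matters, the 4-fluorophenyl ring or the sulfonyl-amino link, remains open. From the compounds shown here alone, how a simple amine or a carboxylic acid would read at this position is also open.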